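The compounds below may be only part of what the source reports. "The series", "measured", "known", "first", "only" and "open" are said of these compounds alone.

In an ADME assay on MRC5 cells (Homo sapiens) for cytotoxicity, read by fluorescence and resazurin assay, with a stated time of 3 days (on this read-out lower numbers stand for stronger inhibition and higher numbers for weaker inhibition), compound 1, with the structure `Cc1ccc(Oc2cccc(CN3CCC(n4cc(C)c(=O)[nH]c4=O)CC3)c2)cc1`, shows only a limit of the assay, > 64000 nM. Compound 2, `Cc1cccc(Oc2cccc(CN3CCC(n4cc(C)c(=O)[nH]c4=O)CC3)c2)c1`, likewise shows only the limit > 64000 nM. The step that the two limits leave unreadable from compound 1 to compound 2 therefore cannot be read. Among the compounds with values here, compound 3, `Cc1cn(C2CCN(Cc3cccc(Oc4ccc(Cl)c(Cl)c4)c3)CC2)c(=O)[nH]c1=O`, is the single compound here with a real number: in this assay compound 3 gives 6100 nM.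

Compound 4, `COc1cccc(Oc2cccc(CN3CCC(n4cc(C)c(=O)[nH]c4=O)CC3)c2)c1`, has not been measured. It differs from compound 3 by 3-methoxyphenyl in place of 3,4-dichlorophenyl on an oxygen on an aromatic ring. Two measured steps speak to this position. Within the data shown here, the step of an at least 10-fold lower number from compound 1 to compound 3 (1.02 log units; beyond the scatter) and the step of an at least 10-fold lower number from compound 2 to compound 3 (1.02 log units; beyond the scatter) both replaced a methylphenyl with the 3,4-dichlorophenyl and each gave a much lower number, arriving at the only value that is not a limit. Going the other way, from the 3,4-dichlorophenyl back to a single small group on the ring, is expected to undo that and give a higher number, most likely back at the limit (the limit of > 64000 nM in this assay, at which 2 of the 3 values shown sit). The expected step is a 7.4-fold higher number from compound 3 to compound 4 (0.87 log units; beyond the scatter), so compound 4 is estimated at 45000 nM, within 12000 nM to 130000 nM.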

Compound 4, half-maximal inhibitory concentration: 25300 nM
Beside the measured number, compound 4's estimate is 1.8-fold (0.25 log units) above it; the measured number falls inside the stated range.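

In this assay, the 3-methoxyphenyl group gives a readable number with no chlorine on the ring, and the change from the 3,4-dichlorophenyl group is a 4.1-fold higher number from compound 3 to compound 4 (0.62 log units; beyond the scatter), so removing that group does not by itself return the number to the limit. The methyl and methoxy groups also differ, even though both keep a single group on the ring: the change from methyl to methoxy is an at least 2.5-fold lower number from compound 2 to compound 4 (0.40 log units; beyond the scatter), and the change from the 4-methylphenyl group gives an at least 2.5-fold lower number from compound 1 to compound 4 (0.40 log units; beyond the scatter). Both sizes are minimums, since compounds 1 and 2 each sit at a limit of the assay: the limit of > 64000 nM in this assay, at which 2 of the 4 values shown sit.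

The compounds shown leave open whether the oxygen of the methoxy group matters or whether other groups would do the same. A 3-chlorophenyl or 3-aminophenyl group at this position would help separate these possibilities.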